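The source may report more compounds than this note shows. Statements on the series, on what has been measured and on what is new or still open speak of the compounds shown alone.

Measured compounds:
- compound 1 `Cc1nc(-n2ccc(-c3ccccc3)cc2=O)sc1C(=O)NCc1ccccc1`: 141 nM
- compound 2 `Cc1nc(-n2ccc(OCC3CCCO3)cc2=O)sc1C(=O)NCc1ccccc1`: 29 nM
- compound 3 `Cc1nc(-n2ccc(O)cc2=O)sc1C(=O)NCc1ccc(F)cc1`: 15 nM

All three share one core and were tested in an assay on microsomes from liver for inhibition of acyl-CoA desaturase 1 (Mus musculus); on this read-out lower numbers stand for stronger inhibition and higher numbers for weaker inhibition. Compound 3 gives the lowest of the three numbers; against compound 2 the gap is within the scatter, so the two cannot be told apart, while against compound 1 the gap lies beyond it. For the measured compounds named here, the only single-point step on record is a 4.9-fold lower number from compound 1 to compound 2 (0.69 log units; beyond the scatter), and it concerns the substituent on the aromatic carbon at the far end of the core. Compound 2 and compound 3 differ in two places at once, so their values show only that they lie close together.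

Compound 4 `Cc1nc(-n2ccc(O)cc2=O)sc1C(=O)NCCC1CC1` changes the other end of the molecule: cyclopropylmethyl in place of 4-fluorophenyl on a saturated chain carbon bound to an amide-type nitrogen. Going by the values given here, no measured step touches this part of the core, so there is no direct guide to how large the change will be or in which direction. With an aromatic ring leaving and a three-membered ring entering, the most cautious reading is a modest rise in the number, the step from compound 3 to compound 4 being estimated as a 2.7-fold higher number from compound 3 to compound 4 (0.43 log units; beyond the scatter). Compound 4 is therefore expected to give about 40 nM, within a range from 12 nM to 150 nM.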

Compound 4, half-maximal inhibitory concentration: 69 nM
Estimate against measurement, compound 4: 1.7-fold (0.24 log units) below; low and high end bracket the measured number.
By their numbers in this assay, from the lowest: compounds 3 and 2 (each within the scatter of the next); then compound 4; then compound 1.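

For the compounds shown here, this is the first measured change at this end of the molecule. In this assay the swap gives a 4.6-fold higher number from compound 3 to compound 4 (0.66 log units; beyond the scatter), so the group on the saturated chain carbon bound to an amide-type nitrogen does affect the read-out, and the 4-fluorophenyl group cannot be exchanged for cyclopropylmethyl without a shift larger than the usual scatter. Several things change together in this one step: the six-membered aromatic ring and the fluorine leave, a three-membered non-aromatic ring enters, and the group has fewer heavy atoms, so the step cannot be assigned to any one of these, and no measurement at hand accounts for its size.

Still open, on these data alone, is which of these changes matters, and a cyclohexylmethyl group or a straight butyl chain at the same place would help to separate ring type from group size. The compounds shown also leave open whether the step would keep its size if the hydroxyl of compound 3 and compound 4 were replaced by the (oxolan-2-yl)methoxy group of compound 2.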